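The source may report more compounds than this note shows. Statements on the series, on what has been measured and on what is new or still open speak of the compounds shown alone.

Measured so far:
- compound 1 `Cc1nc(-c2ccc(F)cc2)c(C(=O)N2CCN(c3cccc(Cl)c3)CC2)o1` gives 40.1 nM in a functional assay on HL-60 cells (Homo sapiens) for inhibition, read by MTT assay, with a stated time of 72 h; a lower number here means a stronger inhibitor, a higher number a weaker inhibitor
- compound 2 `Cc1ccc(N2CCN(C(=O)c3oc(C)nc3-c3ccccc3)CC2)cc1` gives > 1000 nM in this assay
- compound 3 `COc1cc(OC)cc(N2CCN(C(=O)c3oc(C)nc3-c3ccccc3F)CC2)c1` gives 10.3 nM in this assay

Compound 1 and compound 3 both give numbers in this assay, whereas compound 2 gives none. The value of compound 2 is a limit of the assay, not a number: it sits at the limit of > 1000 nM in this assay, at which 1 of the 3 values shown sits, so all that is known is that compound 2 is a weak inhibitor there.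

Compound 4 `Cc1nc(-c2ccccc2)c(C(=O)N2CCN(c3c(C)cccc3C)CC2)o1` has not been measured yet. It differs from compound 2 in one place: 2,6-dimethylphenyl in place of 4-methylphenyl on an amine nitrogen in a ring. Among the measured compounds shown here, no step between two measured compounds shows this particular exchange, so there is no direct guide to its size or direction. Compound 1 and compound 3, which carry other groups on the same ring nitrogen, give far stronger inhibition than the limit seen for compound 2, which leaves open whether a change at this position can recover activity. Compound 4 is therefore expected to land around 700 nM, within a wide range from 120 nM to 4000 nM, which would mean an estimated step of an at least 1.4-fold lower number from compound 2 to compound 4 (0.15 log units; that floor lies within the scatter).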

Compound 4, half-maximal inhibitory concentration: 146 nM
The estimate for compound 4 lay 4.8-fold (0.68 log units) above the measured number, within the range that was stated.
By their numbers in this assay, from the lowest: compound 3; then compound 1; then compound 4. At a limit, above all of these: compound 2.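

In this assay, exchanging only the group on this ring nitrogen moves the result clearly, with 2,6-dimethylphenyl in place of 4-methylphenyl giving an at least 6.8-fold lower number from compound 2 to compound 4 (0.83 log units; beyond the scatter). The value of compound 2 is a limit and not a number: the limit of > 1000 nM in this assay, at which 1 of the 4 values shown sits. Among the compounds shown here, the step is therefore a lower bound on the true change, and it gives the first direct evidence that activity at this position depends on which methyl-bearing phenyl group is present, since the rest of the structure stays the same.

This single exchange alters both the number of methyl groups and where they sit on the phenyl ring, so it cannot show which of the two matters, and a 2-methylphenyl group on the same nitrogen would help to separate them. Going by these compounds, how a phenyl ring carrying an amine or a carboxylic acid would behave here also remains open.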